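Pyrrolidinylmethoxy pyridine ethers: bromo to acetyl exchange

The source may report more compounds than this note shows. Statements on the series, on what has been measured and on what is new or still open speak of the compounds shown alone.

Measured so far, in an assay on membranes from brain for displacement of a labelled ligand from Neuronal acetylcholine receptor; alpha4/beta2 (Rattus norvegicus); on this read-out higher numbers stand for weaker inhibition and lower numbers for stronger inhibition:
compound 1 `CSc1ncccc1OC[C@@H]1CCCN1C` gives 559 nM
compound 2 `CN1CCC[C@H]1COc1cnccc1Br` gives 28 nM
compound 3 `CN1CCC[C@H]1COc1cncc(Br)c1` gives 0.27 nM

Compound 3 gives the lowest number of the three; its nearest neighbour is compound 2 and its most distant is compound 1, both gaps beyond the scatter, so compound 3 is the strongest binder of the set.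

Compound 4 `CC(=O)c1cncc(OC[C@@H]2CCCN2C)c1` has not yet been measured. It differs from compound 3 in one place: acetyl in place of bromo on an aromatic carbon. Among the measured compounds shown here, no measured pair in the set isolates this exchange, so no measured step speaks to it directly.

For compound 4 a step toward weaker binding is expected in this assay, of a size a 30-fold higher number from compound 3 to compound 4 (1.47 log units; beyond the scatter), beyond the scatter. The estimate for compound 4 is 8 nM, within a range from 1.5 nM to 40 nM.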

Compound 4, inhibition constant: 1.19 nM
For compound 4 the middle estimate is 6.7-fold (0.83 log units) above the measured one; measured number outside the range, below it.
By their numbers in this assay, from the lowest: compound 3; then compound 4; then compound 2; then compound 1.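

In this assay, acetyl in place of bromo on this aromatic carbon, two atoms from the ring nitrogen, gives a modest step (a 4.4-fold higher number from compound 3 to compound 4 (0.64 log units; beyond the scatter)) that lies beyond the scatter. With three heavy atoms in place of one and a hydrogen-bond acceptor added, compound 4 still binds strongly at 1.19 nM, so bromo is not required at this position.

As far as these compounds go, whether an amine, a carboxylic acid or a longer chain at this position would hold binding remains open. Nothing at hand accounts for the size of the step.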